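A Tethered Piperidine Versus a Ring Bound Directly

A few compounds are considered here, and "the series" means these few. Any claim that something is new, unique, unknown or untested is made for them only; others in the source may bear on it.

Compound 3 `COc1ccc(Br)cc1CCc1c(F)cccc1C(=O)/N=C(\N)NCCCN1CCCCC1` is the stronger of the two measured compounds in a functional assay for antagonist activity at Melanocortin receptor 4 (Homo sapiens), read by cAMP accumulation (on this read-out lower numbers stand for stronger inhibition and higher numbers for weaker inhibition), where compound 3 gives 330 nM. Compound 1 `COc1ccc(Br)cc1CCc1c(F)cccc1C(=O)/N=C(\N)NCCN1CCCC1` differs only in the amine-bearing chain end, and in this assay compound 1 gives 4500 nM. The step between them, a 14-fold lower number from compound 1 to compound 3 (1.13 log units; beyond the scatter), shows how strongly this assay responds to a change at that position. Compound 2 `CCCC/N=C(/N)NC(=O)c1cccc(F)c1CCc1cc(Br)ccc1OC`, with a butyl group in place of the amine-bearing chain, gives "not determined" (no result reported) in this assay, so it adds no number to the comparison.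

Compound 4 `COc1ccc(Br)cc1CCc1c(F)cccc1C(=O)/N=C(\N)NCC1CCNCC1` keeps the shared core and alters the chain again: piperidin-4-yl in place of 2-(piperidin-1-yl)ethyl on a saturated chain carbon bound to an amine nitrogen. Within the data shown here, the only measured step that bears on this change is the one from compound 1 to compound 3, which was large, and it concerned the same chain end. That step shows the position is sensitive, but it does not show the direction for a ring bound directly to the chain carbon. The step from compound 3 to compound 4 is therefore expected to be wide in its uncertainty, with compound 4 estimated at 1500 nM in this assay, between 300 nM and 8000 nM, corresponding to an expected 4.5-fold higher number from compound 3 to compound 4 (0.66 log units; beyond the scatter).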

Compound 4, half-maximal inhibitory concentration: 31 nM
The estimate for compound 4 lay 48-fold (1.68 log units) above the measured number; measured number below the stated range.
By their numbers in this assay, from the lowest: compound 4; then compound 3; then compound 1.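

In this assay, the earlier pair showed only that the amine-bearing chain end responds strongly when one ring-bearing chain replaces another. Piperidin-4-yl in place of 2-(piperidin-1-yl)ethyl on a saturated chain carbon bound to an amine nitrogen now gives an 11-fold lower number from compound 3 to compound 4 (1.03 log units; beyond the scatter), and the whole span from the weakest to the strongest of the measured compounds is a 150-fold lower number from compound 1 to compound 4 (2.16 log units; beyond the scatter), so this position can carry a much smaller gain or loss than the first step alone suggested, and here the change is a further large gain. No measurement offered here accounts for this gain.

The change alters two counted features at once, going from 8 heavy atoms to 6 and from 0 hydrogen-bond donors to 1, and the compounds shown do not separate these, which a group such as 1-methylpiperidin-4-yl or 2-(piperidin-4-yl)ethyl on the same chain carbon could begin to do. From the compounds shown here alone, compound 2, with its butyl group, has no number, so steps involving it cannot be read, and whether a ring amine at this position is needed at all stays open.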